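A few compounds are considered here, and "the series" means these few. Any claim that something is new, unique, unknown or untested is made for them only; others in the source may bear on it.

In a functional assay on DU-145 cells (Homo sapiens) for antiproliferative activity, read by MTT assay, with a stated time of 24 h (on this read-out higher numbers stand for weaker inhibition and lower numbers for stronger inhibition), the three measured compounds give the following numbers:

Compound 1, `COc1ccc(-c2cc(C(=O)/C=C/c3ccccc3)nc3cc(-c4ccccc4)nn23)cc1OC`, gives 15600 nM.
Compound 2, `COc1ccc(-c2cc(C(=O)/C=C/c3ccc(C)cc3)nc3cc(-c4ccccc4)nn23)cc1OC`, gives 19500 nM.
Compound 3, `COc1cc(-c2cc(/C=C/C(=O)c3ccc(C)cc3)nc3cc(-c4ccccc4)nn23)cc(OC)c1OC`, gives 27100 nM.

Compounds 1 and 2 share one core, and the difference between them is hydrogen in place of methyl on an aromatic carbon. The step that this change made was a 1.3-fold lower number from compound 2 to compound 1 (0.10 log units; within the scatter), so the two numbers are not separated by more than the usual scatter of the measurement. Compound 3 carries a different core; the difference between the two cores is not broken down here, and all that can be said is that its number in this assay and the numbers of compounds 1 and 2 lie within the scatter of one another.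

Compound 4, `COc1cc(-c2cc(/C=C/C(=O)c3ccccc3)nc3cc(-c4ccccc4)nn23)cc(OC)c1OC`, has not yet been measured. It differs from compound 3 by hydrogen in place of methyl on an aromatic carbon. This is the same change as that made between compounds 2 and 1: the group that leaves, the group that enters and the place described for both are identical, word for word. Going by the values given here, the only measured example of the change thus stands on the other core, and it produced a step within the scatter.

On that basis the step from compound 3 to compound 4 in this assay is expected to be small, a 1.3-fold lower number from compound 3 to compound 4 (0.11 log units; within the scatter), resting on the earlier step of a 1.3-fold lower number from compound 2 to compound 1 (0.10 log units; within the scatter). Accordingly, compound 4 is estimated to give 21000 nM, with a range expected from 9000 nM to 50000 nM.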

Compound 4, half-maximal inhibitory concentration: 34300 nM
Compound 4: middle estimate off by 1.6-fold (0.21 log units), on the low side; the range from low to high includes it.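

On the second core, the exchange of 4-methylphenyl for phenyl gave a 1.3-fold higher number from compound 3 to compound 4 (0.10 log units; within the scatter), so in this assay this change again leaves the number inside the usual scatter of the measurement. Set beside the earlier example, the two steps cannot be told apart, and the printed directions of the steps carry no weight: the same change on two cores in this assay, a 1.3-fold lower number (0.10 log units; within the scatter) from compound 2 to compound 1 and a 1.3-fold higher number (0.10 log units; within the scatter) from compound 3 to compound 4, 1.6-fold (0.20 log units) apart, within the scatter of two such steps

Going by these compounds alone, what this shows is that, on the two cores seen here, the change from methyl to hydrogen has not produced a step that can be read as real in this assay, and that a prediction carried from one core to the other holds only in that limited sense; it does not show that the methyl group is without any effect, nor that the two cores respond identically, since steps this small could hide a modest difference and only one pair of examples exists.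

The compounds shown leave open whether a different group on that aromatic carbon, such as chlorine, a methoxy group, an amine or a carboxylic acid, would move the number beyond the scatter on either core. They also leave open whether the exchange of methyl for hydrogen stays this small on any other core or in any other assay.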